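From Ethoxy to Fluoro on the Aromatic Ring

The source may report more compounds than this note shows. Statements on the series, on what has been measured and on what is new or still open speak of the compounds shown alone.

In a functional assay on HL-60 cells (Homo sapiens) for cytotoxicity, read by WST assay, with a stated time of 48 h (on this read-out higher numbers stand for an effect only at larger amounts of compound and lower numbers for an effect already at smaller amounts), three compounds sharing one core have been measured. Compound 1 `O=C1OC[C@H](Cc2ccccc2O)[C@H]1Cc1ccc(Cl)c(Cl)c1`, with a hydrogen on the oxygen on its aromatic ring, gives 33000 nM. Compound 2 `COc1ccccc1C[C@H]1COC(=O)[C@@H]1Cc1ccc(Cl)c(Cl)c1` gives 14000 nM, and compound 3 `CCOc1ccccc1C[C@H]1COC(=O)[C@@H]1Cc1ccc(Cl)c(Cl)c1` gives 15000 nM. Compound 3 therefore stands level with compound 2, as a 1.1-fold higher number from compound 2 to compound 3 (0.03 log units; within the scatter) shows, and clearly apart from compound 1, as a 2.2-fold lower number from compound 1 to compound 3 (0.34 log units; beyond the scatter) shows.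

Compound 4 `O=C1OC[C@H](Cc2ccccc2F)[C@H]1Cc1ccc(Cl)c(Cl)c1` carries fluoro in place of ethoxy on an aromatic carbon. For the measured compounds named here, no measured compound has fluoro, so the evidence is indirect. The steps at this same place are small: a 2.4-fold lower number from compound 1 to compound 2 (0.37 log units; beyond the scatter) for the methyl group and a 2.2-fold lower number from compound 1 to compound 3 (0.34 log units; beyond the scatter) for the ethyl group, both only modest. These suggest that this assay responds little to changes here, so no step beyond the scatter is expected. The expected change is a 1.3-fold higher number from compound 3 to compound 4 (0.12 log units; within the scatter). Compound 4 is estimated at 20000 nM, with an expected range of 9000 nM to 45000 nM.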

Compound 4, half-maximal effective concentration: 28000 nM
For compound 4 the middle estimate is 1.4-fold (0.15 log units) below the measured one; low and high end bracket the measured number.
By their numbers in this assay, from the lowest: compounds 2, 3, 4 and 1 (each within the scatter of the next, the first and the last beyond it).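

For the compounds shown here, every compound measured before compound 4 has an oxygen on this aromatic carbon, so the earlier steps only compared hydroxy, methoxy and ethoxy with one another. Fluoro brings no oxygen and has fewer heavy atoms than ethoxy, yet in this assay the result is a 1.9-fold higher number from compound 3 to compound 4 (0.27 log units; within the scatter) and a 2.0-fold higher number from compound 2 to compound 4 (0.30 log units; within the scatter) and also a 1.2-fold lower number from compound 1 to compound 4 (0.07 log units; within the scatter), so compound 4 cannot be told apart from any of the three, even though compound 1 is separated from compound 2 and compound 3 by more than the scatter. Nothing available here explains these numbers.

Going by these compounds, the effect of an amine, a carboxylic acid or a longer chain such as butoxy on this aromatic carbon remains open. So does whether a larger halogen such as bromo would fit the same picture.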